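A few compounds are considered here, and "the series" means these few. Any claim that something is new, unique, unknown or untested is made for them only; others in the source may bear on it.

Three compounds share one core and differ at the chain on the ring amine. Compound 1 `C=C(C)CCN1CCC2(CC1)OC(OC)Cc1c2cnn1-c1ccccc1` carries a 3-methylbut-3-en-1-yl chain and a methoxy on the core; in an assay for displacement of a labelled ligand from Sigma non-opioid intracellular receptor 1 (Cavia porcellus), read by scintillation counting, with a stated time of 180 min (on this read-out lower numbers stand for stronger inhibition and higher numbers for weaker inhibition), compound 1 gives 1.6 nM. Compound 2 `c1ccc(CN2CCC3(CC2)OCCc2c3cnn2-c2ccccc2)cc1` carries a benzyl chain, and in this assay compound 2 gives 1.71 nM. Compound 3 `CC(C)CCN1CCC2(CC1)OCCc1c2cnn1-c1ccccc1` carries an isopentyl chain, and in this assay compound 3 gives 0.98 nM. Going by the values given here, all three numbers sit within the scatter of one another: the one step counted, a 1.7-fold lower number from compound 2 to compound 3 (0.24 log units; within the scatter), is small, and the numbers of compound 3 and compound 1 are likewise close.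

Compound 4 `C=C(C)CCN1CCC2(CC1)OCCc1c2cnn1-c1ccccc1` has not yet been measured. It differs from compound 3 by 1-methylethenyl in place of isopropyl on a saturated chain carbon, two bonds along the chain from an amine nitrogen in a ring. Among the compounds with values here, no measured step covers this exact change; the nearest information is the chain of compound 1, whose number stands close to that of compound 3 while the core also differs. The one listed step, a 1.7-fold lower number from compound 2 to compound 3 (0.24 log units; within the scatter), shows that larger chain changes left the number within the scatter. For compound 4 the step of a 1.3-fold higher number from compound 3 to compound 4 (0.12 log units; within the scatter) is therefore expected to be small. The estimate for compound 4 in this assay is 1.3 nM, with a range from 0.5 nM to 3.5 nM.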

Compound 4, inhibition constant: 0.97 nM
The estimate for compound 4 lay 1.3-fold (0.13 log units) above the measured number; the measured number falls inside the stated range.
By their numbers in this assay, from the lowest: compounds 4, 3, 1 and 2 (each within the scatter of the next).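

In this assay, the exchange of isopropyl for 1-methylethenyl on a saturated chain carbon, two bonds along the chain from an amine nitrogen in a ring, gives a 1.0-fold lower number from compound 3 to compound 4 (0.00 log units; within the scatter), so adding this double bond leaves the number unmoved. With the chain held the same, methoxy on a saturated ring carbon can now be read alone, and its removal gives a 1.6-fold lower number from compound 1 to compound 4 (0.22 log units; within the scatter), while the chain change from the benzyl compound gives a 1.8-fold lower number from compound 2 to compound 4 (0.25 log units; within the scatter), so both steps stay within the scatter. Nothing at hand accounts for how small these steps are.

The compounds shown leave open whether a hydroxyl, an amine or a carboxylic acid on the chain would move the number beyond the scatter. They also leave open what a longer chain would do.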